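Fluorophenyl ketone on a weakly cytotoxic triazolothiadiazine

The source may hold more compounds than are shown below. What is called first, only, known or untested is meant among the compounds shown, and "the series" means these compounds.

Compound 1, `COc1cc(-c2nnc3n2NC(c2ccco2)C(C(=O)c2ccc(-c4ccccc4)cc2)S3)cc(OC)c1OC`: > 100000 nM
Compound 2, `COc1cc(-c2nnc3n2NC(c2ccco2)C(C(=O)c2ccccc2C)S3)cc(OC)c1OC`: 63000 nM
Compound 3, `COc1cccc(C(=O)C2Sc3nnc(-c4cc(OC)c(OC)c(OC)c4)n3NC2c2ccco2)c1`: > 100000 nM

Compound 3 stands at the edge of what a functional assay on HepG2 cells (Homo sapiens) for cytotoxicity, read by MTT assay, with a stated time of 48 h (on this read-out lower numbers stand for stronger inhibition and higher numbers for weaker inhibition), reports. In this assay compound 3 gives > 100000 nM, and that is a limit of the assay rather than a number. Compound 4, `COc1cc(-c2nnc3n2NC(c2ccco2)C(C(=O)c2ccc(F)cc2)S3)cc(OC)c1OC`, differs from compound 3 in one place: 4-fluorophenyl in place of 3-methoxyphenyl on a carbonyl carbon. Among the measured compounds shown here, three measured steps touch this carbonyl-bound aryl group. The step that the two limits leave unreadable from compound 1 to compound 3, the step of an at least 1.5-fold higher number from compound 2 to compound 3 (0.20 log units; that floor lies within the scatter) and the step of an at least 1.5-fold lower number from compound 1 to compound 2 (0.20 log units; that floor lies within the scatter) all lie within the usual scatter or cannot be read, and the series as a whole sits near (the limit of > 100000 nM in this assay, at which 2 of the 3 values shown sit). Nothing among these steps points to a change beyond the scatter for compound 4, so the expected step is an at least 1.1-fold lower number from compound 3 to compound 4 (0.04 log units; that floor lies within the scatter) in this assay. Compound 4 is therefore expected to come in around 90000 nM, with a range of 40000 nM to 200000 nM, and a limit rather than a number is the likelier report.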

Compound 4, half-maximal inhibitory concentration: > 100000 nM
Compound 4: only a limit was reported; the forecaster's own chance of this, stated with the estimate: 55%; at least 1.1-fold (0.04 log units) between middle value and limit.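

In this assay compound 4 gives > 100000 nM, which is a limit of the assay and not a number. Among the compounds shown here, the 4-fluorophenyl group on the carbonyl carbon thus ends at the same limit as 3-methoxyphenyl and 4-phenylphenyl, so the steps that compare these three cannot be read, and the one readable step is an at least 1.5-fold higher number from compound 2 to compound 4 (0.20 log units; that floor lies within the scatter). This change therefore adds no step shown to lie beyond the scatter, and the series sits more firmly at the edge of the read-out: the limit of > 100000 nM in this assay, at which 3 of the 4 values shown sit.

Going by these compounds, whether an amine or a carboxylic acid in place of fluoro on this aromatic ring would give a number rather than a limit stays open. On these data alone, with compound 2 the only one of the four to give a number, the size of any difference among compound 1, compound 3 and compound 4 also remains unknown.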